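Urea aryl swap on a pyrazole series against colon cancer cells

The compounds below may be only part of what the source reports. "The series", "measured", "known", "first", "only" and "open" are said of these compounds alone.

Compound 1 `COc1cc(-c2nn(-c3cccc(NC(=O)Nc4cc(C(F)(F)F)cc(C(F)(F)F)c4)c3)cc2-c2ccncc2)ccc1Cl` gives 702 nM in a functional assay on HT-29 cells (Homo sapiens) for inhibition, read by sulforhodamine B assay, with a stated time of 48 h; on this read-out higher numbers stand for weaker inhibition of growth and lower numbers for stronger inhibition of growth.
Compound 2 `COc1cc(-c2nn(-c3cccc(NC(=O)Nc4ccc(Cl)c(Cl)c4)c3)cc2-c2ccncc2)ccc1Cl` gives 1240 nM in this assay.

Compound 2 holds the higher of the two numbers, but its gap to compound 1 is within the scatter of repeated measurements, so the two stand together rather than in any order. Compound 3 `COc1cc(-c2nn(-c3cccc(NC(=O)Nc4cccc(C(F)(F)F)c4)c3)cc2-c2ccncc2)ccc1Cl` has not yet been measured. It differs from compound 2 in one place: 3-(trifluoromethyl)phenyl in place of 3,4-dichlorophenyl on an amide-type nitrogen, with the other neighbour of that nitrogen being a carbonyl carbon; cut one bond further out, the change reads (3,4-dichlorophenyl)amino to (3-(trifluoromethyl)phenyl)amino. Going by the values given here, no step between measured compounds in this assay is available to calibrate the change. Since compound 1 and compound 2 carry two different substituted phenyl groups at the same place and land within the scatter of each other, a third substituted phenyl is expected to land near them, with a small step upward from compound 2 to compound 3 of a 1.2-fold higher number from compound 2 to compound 3 (0.08 log units; within the scatter) that itself need not exceed the scatter. Compound 3 is therefore estimated at 1500 nM, within 600 nM to 4000 nM.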

Compound 3, concentration for 50% growth inhibition: 748 nM
Compound 3: the middle estimate sits 2.0-fold (0.30 log units) above what was measured; the range from low to high includes it.
By their numbers in this assay, from the lowest: compounds 1, 3 and 2 (each within the scatter of the next).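

In this assay, going by these compounds alone, the first two steps that can be read at this place are both small. 3-(Trifluoromethyl)phenyl in place of 3,4-dichlorophenyl on the amide-type nitrogen gives a 1.7-fold lower number from compound 2 to compound 3 (0.22 log units; within the scatter), so exchanging these two substituted phenyl groups moves the read-out by no more than repeated measurements would. Hydrogen in place of trifluoromethyl on an aromatic carbon gives a 1.1-fold higher number from compound 1 to compound 3 (0.03 log units; within the scatter), which shows that one of the two trifluoromethyl groups of compound 1 can be absent with no separable difference, and no measurement beyond these growth-inhibition numbers bears on what lies behind either step.

On these data alone, all three compounds carry chlorine or trifluoromethyl on this phenyl group, so it remains open whether the flat picture extends to an unsubstituted phenyl, or to a phenyl bearing a carboxylic acid or a dimethylamino group. As far as these compounds go, it is also open whether a step beyond the scatter appears at this place with a pyridine ring or a longer alkyl chain on the urea nitrogen in place of the phenyl group.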